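Cyclopropyl to tert-butyl on the shared core: notes

This account rests on a few compounds, and the source may have more. Where it says the series, first, only, none or still open, it means among the compounds named here.

Values in a functional assay on SW1573 cells (Homo sapiens) for antiproliferative activity, read by sulforhodamine B assay, with a stated time of 48 h; a lower number here means a stronger inhibitor of growth, a higher number a weaker inhibitor of growth:
compound 1, `COC(=O)C#CC(O/C=C/C(=O)OC)C1CC1`: 1800 nM
compound 2, `CC1CCC(C(C)C)C(OC(=O)C#CC(O/C=C/C(=O)OC2CC(C)CCC2C(C)C)C(C)C)C1`: > 100000 nM, a limit of the assay, not a number

Among the compounds with values here, compound 1 is the only compound of the two with a numeric value in this assay, so it stands alone as the reference point. Compound 2 sits at the limit of > 100000 nM in this assay, at which 1 of the 2 values shown sits. Within the data shown here, compound 2 differs from compound 1 in several places at once, so no single step between measured compounds can be read from the pair; the two values show only that compound 1 gives a number where compound 2 gives none.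

Compound 3, `COC(=O)C#CC(O/C=C/C(=O)OC)C(C)(C)C`, differs from compound 1 by tert-butyl in place of cyclopropyl on a saturated chain carbon bound to an oxygen on an unsaturated carbon and a triple-bonded carbon. Among the measured compounds shown here, no measured step of this kind exists in the set, so the expectation rests on compound 1 alone. The change is small in atom count and keeps donor and acceptor count unchanged, so a step of no more than the usual scatter is expected, with weaker inhibition of growth taken as somewhat more likely than stronger. Compound 3 is expected to give 2500 nM, within 800 nM to 8000 nM, in this assay. The expected step is a 1.4-fold higher number from compound 1 to compound 3 (0.14 log units; within the scatter).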

Compound 3, concentration for 50% growth inhibition: 3000 nM
Beside the measured number, compound 3's estimate is 1.2-fold (0.08 log units) below it; the range from low to high includes it.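

In this assay, tert-butyl in place of cyclopropyl on a saturated chain carbon bound to an oxygen on an unsaturated carbon and a triple-bonded carbon gives a 1.7-fold higher number from compound 1 to compound 3 (0.22 log units; within the scatter). Within the data shown here, this is the first change at a single place that can be read, and it shows that the three-membered ring can be exchanged for an open tert-butyl at this position with no step beyond the scatter. No measured property available here bears on this step.

Among these compounds, compound 2 differs from compound 1 in several places and carries only a limit of the assay, so no step involving it can be read, and what separates it from compound 1 and compound 3 stays open. Also open, going by these compounds, is whether a phenyl ring, a longer chain or a chain carrying an amine at this same carbon would stay in the range of compound 1 and compound 3 or leave it.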